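This account rests on a few compounds, and the source may have more. Where it says the series, first, only, none or still open, it means among the compounds named here.

Measured so far in a physicochemical assay for lipophilicity, read by LC-MS, in phosphate buffer, measured as octanol-water partition, with a stated time of 30 min, at pH 7.4, tested at 200 mM; on this read-out lower numbers stand for lower lipophilicity and higher numbers for higher lipophilicity:
- compound 1, `Cc1cccnc1Oc1ccc2nc(COc3cccc(C(=O)O)c3)n(C)c2c1`: 0.9
- compound 2, `Cn1c(COc2cccc(C(=O)O)c2)nc2ccc(Oc3ncccc3F)cc21`: 0.6
- compound 3, `Cn1c(COc2cccc(C(=O)O)c2)nc2ccc(Oc3ncc(Cl)cc3F)cc21`: 1.3

In this assay compound 3 stands highest of the three. The steps among them: a number 0.30 log units higher from compound 2 to compound 1 (within the scatter); a number 0.40 log units higher from compound 1 to compound 3 (beyond the scatter); a number 0.70 log units higher from compound 2 to compound 3 (beyond the scatter). The two cores differ by chloro in place of hydrogen on an aromatic carbon.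

Compound 4, `Cc1cc(Cl)cnc1Oc1ccc2nc(COc3cccc(C(=O)O)c3)n(C)c2c1`, is not yet measured. It differs from compound 3 by methyl in place of fluoro on an aromatic carbon. The same change has been made once before, from compound 2 to compound 1, as methyl in place of fluoro on an aromatic carbon, where it gave a number 0.30 log units higher from compound 2 to compound 1 (within the scatter). The surroundings of the place are not identical: in compound 3 the carbon that carries the fluoro is also meta to a chloro group, which is not so in compound 2, so this is the same kind of change rather than the same change.

On that single earlier step, a step of a number 0.30 log units higher from compound 3 to compound 4 (within the scatter) is expected from compound 3 to compound 4, resting on a number 0.30 log units higher from compound 2 to compound 1 (within the scatter) and on the value of compound 3 at 1.3. Compound 4 is therefore estimated at 1.6, with a likely range from 1.2 to 2.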

Compound 4, distribution coefficient: 1.8
Beside the measured number, compound 4's estimate is 0.20 log units below it; low and high end bracket the measured number.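

In this assay methyl in place of fluoro carries over to the core with the chloro group in the same direction, giving a number 0.50 log units higher from compound 3 to compound 4 (beyond the scatter) and, in the core without chloro, a number 0.30 log units higher from compound 2 to compound 1 (within the scatter) with only the first of the two beyond the scatter. Chloro in place of hydrogen also raises the number on the methyl side, with a number 0.90 log units higher from compound 1 to compound 4 (beyond the scatter) against a number 0.70 log units higher from compound 2 to compound 3 (beyond the scatter) on the fluoro side, and the two changes together give a number 1.20 log units higher from compound 2 to compound 4 (beyond the scatter) as the largest step in the set. Two pairs do not show that the change will hold in other cores or that the chloro group alters its size, and nothing measured here explains either step.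

Still open, going by these compounds, is whether other groups on that aromatic carbon, such as methoxy or nitrile, would fall in the same order as fluoro and methyl. Also open, on these data alone, is whether these steps would hold with trifluoromethyl in place of the chloro group, or with an amide in place of the carboxylic acid.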